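The compounds below may be only part of what the source reports. "The series", "measured", "known", "first", "only" and "open" are said of these compounds alone.

Measured compounds:

Compound 1, `COc1ccccc1N1C(=O)C(C)SC1c1cccc(C(=O)NCCCCc2ccccc2)c1`, gives 94% in a functional assay on MG-63 cells (Homo sapiens) for inhibition, read by CCK-8 assay, with a stated time of 72 h, tested at 1 uM; a higher number here means more inhibition at the concentration tested (going by the name of the read-out), a lower number less inhibition.
Compound 2, `COc1ccccc1N1C(=O)CSC1c1cc(F)cc(C(=O)O)c1`, gives 0% in this assay.
Compound 3, `COc1ccc(C)cc1N1C(=O)CSC1c1cccc(C(=O)NCCCCc2ccccc2)c1`, gives 92% in this assay.

Among these three numbers compound 3 stands second highest. Its nearest neighbour is compound 1, whose number lies within the usual scatter of compound 3, so the two cannot be told apart. For the measured compounds named here, its furthest neighbour is compound 2, whose number lies far below, beyond the scatter; no step between these measured pairs has been worked out, so only the values themselves speak.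

Compound 4, `COc1ccc(OC)c(N2C(=O)CSC2c2cccc(C(=O)NCCCCc3ccccc3)c2)c1`, is not yet measured. It differs from compound 3 in one place: methoxy in place of methyl on an aromatic carbon. The change is small in size and leaves the rest of the shared core untouched, so no step beyond the scatter is expected, in either direction. Compound 4 is therefore estimated at 88%, ranging from 70% to 97%, meaning an expected step of a number 4 percentage points lower from compound 3 to compound 4 (within the scatter) in this assay.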

Compound 4, a percentage reported as inhibition, at one concentration (the size of the read-out at that concentration, not a potency): 92%
The estimate for compound 4 lay 4 percentage points below the measured number, within the range that was stated.
By their numbers in this assay, from the lowest: compound 2; then compounds 3, 4 and 1 (each within the scatter of the next).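

Replacing the methyl with a methoxy, which turns the 2-methoxy-5-methylphenyl group into the 2,5-dimethoxyphenyl group, gives no change at the digits printed from compound 3 to compound 4 (within the scatter) in this assay. This is the first one-place comparison among the compounds shown, and it shows that this ring carbon, para to a methoxy group, can carry one more heavy atom and a hydrogen-bond acceptor with no loss of inhibition beyond the scatter. Nothing measured here explains why the number holds.

Each number is a reading at one concentration, so any difference in potency between compound 3 and compound 4 remains unseen. As far as these compounds go, how inhibition responds to an amine, a carboxylic acid or a longer chain such as butoxy at this position also remains open.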